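Bromophenyl in place of chlorophenyl on the shared core

A few compounds are considered here, and "the series" means these few. Any claim that something is new, unique, unknown or untested is made for them only; others in the source may bear on it.

Measured so far:
- compound 1 `NC1=NC2(CCOCC2)N(OCCCOc2ccccc2Cl)C(N)=N1`: 70 nM
- compound 2 `NC1=NC2(CCSCC2)N(OCCCOc2cccc(Br)c2)C(N)=N1`: 1 nM

In a functional assay on HCT-116 cells (Homo sapiens) for antiproliferative activity, read by MTT assay, with a stated time of 72 h (on this read-out lower numbers stand for stronger inhibition and higher numbers for weaker inhibition), compound 1 gives 70 nM, the highest of the two numbers; compound 2 gives 1 nM, a gap beyond the scatter. Among the measured compounds shown here, the two differ in two places, so no single step is read between them.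

Compound 3 `NC1=NC2(CCOCC2)N(OCCCOc2ccc(Br)cc2)C(N)=N1` keeps the core of compound 1 and changes only one place: 4-bromophenyl in place of 2-chlorophenyl on an oxygen on a saturated carbon. Compound 2 shows that a bromine-bearing phenoxy group can sit on a very low number, though on a different core. A moderate decrease is expected, as a 2.3-fold lower number from compound 1 to compound 3 (0.37 log units; beyond the scatter). Compound 3 is estimated at 30 nM, within 5 nM to 200 nM.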

Compound 3, half-maximal inhibitory concentration: 320 nM
Compound 3: middle estimate off by 11-fold (1.03 log units), on the low side; the whole stated range lies below it.
By their numbers in this assay, from the lowest: compound 2; then compound 1; then compound 3.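

In this assay 4-bromophenyl in place of 2-chlorophenyl on an oxygen on a saturated carbon gives a 4.6-fold higher number from compound 1 to compound 3 (0.66 log units; beyond the scatter), so on the core of compound 1 a bromine-bearing phenyl does not by itself bring a low number. The halogen and its place on the ring change together in this step, so neither can be credited alone. Nothing available accounts for the rise.

Going by these compounds, whether 4-chlorophenyl or 2-bromophenyl would separate these two changes remains open. So does how an amine or a longer chain would fare at this place.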